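Hydroxyaryl in place of pyridinyl: working notes

A few compounds are considered here, and "the series" means these few. Any claim that something is new, unique, unknown or untested is made for them only; others in the source may bear on it.

Values in a functional assay on EC9706 cells (Homo sapiens) for antiproliferative activity, read by MTT assay, with a stated time of 72 h; a lower number here means a stronger inhibitor, a higher number a weaker inhibitor:
- compound 1 `C/C(=N\NC(=O)c1cccc(S(=O)(=O)N2CCOCC2)c1)c1cccc(N)c1`: > 100000 nM (a limit)
- compound 2 `C/C(=N\NC(=O)c1cccc(S(=O)(=O)N2CCOCC2)c1)c1cc(F)ccc1O`: 2210 nM
- compound 3 `O=C(N/N=C/c1ccccn1)c1cccc(S(=O)(=O)N2CCOCC2)c1`: 44300 nM

Of the two actual numbers, the higher belongs to compound 3 at 44300 nM. Compound 2 lies lower, by a margin beyond the scatter. Compound 4 `O=C(N/N=C/c1cc(Cl)ccc1O)c1cccc(S(=O)(=O)N2CCOCC2)c1` carries 5-chloro-2-hydroxyphenyl in place of pyridin-2-yl on a carbon with a double bond to nitrogen.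

Within the data shown here, one measured step bears on this change: an at least 45-fold lower number from compound 1 to compound 2 (1.65 log units; beyond the scatter). There, 5-fluoro-2-hydroxyphenyl replaces 3-aminophenyl at the same place. Compound 1 stands at the limit of > 100000 nM in this assay, at which 1 of the 3 values shown sits, so that step gives a bound and not an exact size. Among the measured compounds shown here, it also starts from a different group, and no measured step isolates the change to compound 4. The closest guide is compound 2 at 2210 nM, which bears the 5-fluoro-2-hydroxyphenyl group but differs from compound 4 in more than that group.

A large step toward a lower number is therefore expected in this assay, with some allowance for these differences. The expected change is a 15-fold lower number from compound 3 to compound 4 (1.17 log units; beyond the scatter). For compound 4 the estimated value is 3000 nM, within an expected range from 700 nM to 13000 nM.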

Compound 4, half-maximal inhibitory concentration: 2150 nM
For compound 4 the middle estimate is 1.4-fold (0.14 log units) above the measured one, within the range that was stated.
By their numbers in this assay, from the lowest: compounds 4 and 2 (each within the scatter of the next); then compound 3. At a limit, above all of these: compound 1.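

In this assay the exchange of pyridin-2-yl for 5-chloro-2-hydroxyphenyl, on a carbon with a double bond to nitrogen, gives a 21-fold lower number from compound 3 to compound 4 (1.31 log units; beyond the scatter) and so puts an exact size on a change at this place. The earlier step at this place started from compound 1, whose value of > 100000 nM is a limit, and it gave only a bound. Among these compounds, both ends of the new step are actual numbers, so its size belongs to a single change on the core of compound 3, whereas compound 2 and compound 4 differ in more than one place and no step between them can be read.

The new step brings in the carbon-only ring, the hydroxyl and the chlorine together, and the compounds shown do not tell these apart; an unsubstituted phenyl, or a methoxy in place of the hydroxyl, would bear on that question. Nothing at hand gives a cause for the size of this step.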